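This account rests on a few compounds, and the source may have more. Where it says the series, first, only, none or still open, it means among the compounds named here.

Measured in a functional assay on Ehrlich cells (Mus musculus) for cytotoxicity, read by LDH release, with a stated time of 48 h; a lower number here means a stronger inhibitor, a higher number a weaker inhibitor:
- compound 1 `COc1ccc(-c2csc(NC(=O)COc3ccc(C(=O)c4ccc(F)cc4)cc3C)n2)cc1`: 5800 nM
- compound 2 `Cc1cc(C(=O)c2cccc(Br)c2)ccc1OCC(=O)Nc1nc(-c2ccccc2)cs1`: 25900 nM

Of these two, compound 2 stands highest at 25900 nM, beyond the scatter from compound 1. Compound 3 `COc1ccc(-c2csc(NC(=O)COc3ccc(C(=O)c4cccc(Br)c4)cc3C)n2)cc1` departs from compound 2 by methoxy in place of hydrogen on an aromatic carbon, phenyl to 4-methoxyphenyl, para to a large group. Compound 1, which also bears 4-methoxyphenyl but differs elsewhere too, gives 5800 nM, so a modest downward change is expected in this assay. The expected size is a 2.4-fold lower number from compound 2 to compound 3 (0.37 log units; beyond the scatter). For compound 3 the estimated value is 11000 nM, with an expected range of 4000 nM to 30000 nM.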

Compound 3, half-maximal inhibitory concentration: 40600 nM
Compound 3: middle estimate off by 3.7-fold (0.57 log units), on the low side; the whole stated range lies below it.
By their numbers in this assay, from the lowest: compound 1; then compounds 2 and 3 (each within the scatter of the next).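

In this assay, methoxy in place of hydrogen, para to a large group, gives a 1.6-fold higher number from compound 2 to compound 3 (0.20 log units; within the scatter), so with 3-bromophenyl on the carbonyl this position shows no readable response to the change. With methoxy held constant, 3-bromophenyl in place of 4-fluorophenyl on a carbonyl carbon gives a 7.0-fold higher number from compound 1 to compound 3 (0.85 log units; beyond the scatter), so the carbonyl substituent, not the methoxy, carries the larger measured step. Nothing available explains either step.

As far as these compounds go, it remains open whether an amine or a carboxylic acid at this position would move the number. Also open, from the compounds shown here alone, is whether methoxy would behave the same with 4-fluorophenyl on the carbonyl.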